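The source may report more compounds than this note shows. Statements on the series, on what has been measured and on what is new or still open speak of the compounds shown alone.

Measured compounds in a functional assay on MCF7 cells (Homo sapiens) for cytotoxicity, read by MTT assay, with a stated time of 4 days; a higher number here means a weaker inhibitor, a lower number a stronger inhibitor:

Compound 1, `Cc1c(O)ccc2c1[C@H](Cn1cc(-c3ccc(F)cc3)nn1)[C@@]13CC(=O)[C@@](C)(CC[C@@H]21)C3`, is reported in this assay only as a limit, > 20000 nM.
Compound 2, `Cc1c(O)ccc2c1[C@H](Cn1cc(-c3ccc(Cl)cc3)nn1)[C@@]13CC(=O)[C@@](C)(CC[C@@H]21)C3`, is likewise reported only as a limit, > 20000 nM.
Compound 3, `Cc1ccc(-c2cn(C[C@H]3c4c(ccc(O)c4C)[C@@H]4CC[C@@]5(C)C[C@]43CC5=O)nn2)cc1`, is also reported only as a limit, > 20000 nM.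

Compound 1 therefore has no numerical position in this assay; its value is a limit, and the two other values shown are limits as well. The change from compound 1 to compound 2, a step that the two limits leave unreadable from compound 1 to compound 2, cannot be sized, and the same holds for a step that the two limits leave unreadable from compound 1 to compound 3 and a step that the two limits leave unreadable from compound 2 to compound 3. The reason is plain: the limit of > 20000 nM in this assay, at which 3 of the 3 values shown sit.

Compound 4, `Cc1ccc(S(=O)(=O)Oc2ccc3c(c2C)[C@H](Cn2cc(-c4ccc(F)cc4)nn2)[C@@]24CC(=O)[C@@](C)(CC[C@@H]32)C4)cc1`, differs from compound 1 in one place: (4-methylphenyl)sulfonyl in place of hydrogen on an oxygen on an aromatic ring. Among the compounds with values here, none of the measured steps touches this oxygen; they all concern the aromatic carbon of the pendant phenyl ring, and all of them are unreadable. No step size can therefore be carried over to this change, and no direction can be drawn from the three limits.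

He expects compound 4 to remain where compound 1 stands, at or near the limit, an estimated 25000 nM in this assay, within an expected range of 8000 nM to 100000 nM. The step that the limit leaves unreadable from compound 1 to compound 4 is expected to be none beyond the scatter, though a numerical value may not be obtained at all.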

Compound 4, half-maximal inhibitory concentration: > 20000 nM
Compound 4: only a limit was reported (the forecaster's own chance of this, stated with the estimate: 75%); the middle value is on the limit's open side.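

In this assay, within the data shown here, compound 4 is reported only as a limit, > 20000 nM, so no step from compound 1 to compound 4 can be read, and the result gives no size for any change among compounds 1 to 4: the limit of > 20000 nM in this assay, at which 4 of the 4 values shown sit.

The compounds shown leave open whether any of these changes alters cytotoxicity at all.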